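Varying the aromatic group on the ring amine nitrogen

The source may report more compounds than this note shows. Statements on the series, on what has been measured and on what is new or still open speak of the compounds shown alone.

Values in an assay on cell membranes for binding affinity to sodium-dependent dopamine transporter (Rattus norvegicus); a higher number here means a weaker inhibitor, a lower number a stronger inhibitor:
compound 1 `Clc1ccc(CN2CCC(CCOC(c3ccccc3)c3ccccc3)CC2)cc1Cl` — 85.7 nM
compound 2 `COc1ccc(CN2CCC(CCOC(c3ccccc3)c3ccccc3)CC2)cc1` — 27.8 nM
compound 3 `c1ccc(C(OCCC2CCN(Cc3cccnc3)CC2)c2ccccc2)cc1` — 48.6 nM

Compound 3 is separated from both other compounds by steps within the scatter: a 1.8-fold lower number from compound 1 to compound 3 (0.25 log units; within the scatter) and a 1.7-fold higher number from compound 2 to compound 3 (0.24 log units; within the scatter). For the measured compounds named here, the only step beyond the scatter in the set is a 3.1-fold lower number from compound 1 to compound 2 (0.49 log units; beyond the scatter).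

Compound 4 `c1ccc(C(OCCC2CCN(Cc3cc4ccccc4s3)CC2)c2ccccc2)cc1` differs from compound 3 by 1-benzothiophen-2-yl in place of pyridin-3-yl on a saturated chain carbon bound to an amine nitrogen in a ring. Going by the values given here, no measured step swaps a single ring for a fused ring system at this position, so the precedent is indirect: the measured steps show that exchanging the aromatic group here moves the number little or at most modestly. For compound 4 in this assay a step of no more than that size is therefore expected, with no firm direction, giving an estimate of 40 nM with a range of 12 nM to 160 nM. This expected value corresponds to a 1.2-fold lower number from compound 3 to compound 4 (0.08 log units; within the scatter).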

Compound 4, half-maximal inhibitory concentration: 172 nM
For compound 4 the middle estimate is 4.3-fold (0.63 log units) below the measured one, outside the stated range (above it).
By their numbers in this assay, from the lowest: compounds 2, 3, 1 and 4 (each within the scatter of the next, the first and the last beyond it).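

A fused ring system at this position can move the number beyond the scatter, both against pyridin-3-yl (a 3.5-fold higher number from compound 3 to compound 4 (0.55 log units; beyond the scatter)) and against 4-methoxyphenyl (a 6.2-fold higher number from compound 2 to compound 4 (0.79 log units; beyond the scatter)). Against 3,4-dichlorophenyl the step stays within the scatter (a 2.0-fold higher number from compound 1 to compound 4 (0.30 log units; within the scatter)), so the fused group does not set compound 4 apart from every single-ring compound. No measured evidence accounts for these steps.

From the compounds shown here alone, whether the fused ring or its sulfur drives the shift remains open. A 1-benzofuran-2-yl or naphthalen-2-yl group in the same place would separate the two.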